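Butyl to Cyclohexyl on the Aromatic-Ring Nitrogen

This account rests on a few compounds, and the source may have more. Where it says the series, first, only, none or still open, it means among the compounds named here.

Compound 1 `CCCNc1nc2c(NC3CCCC3)ncnc2n1[C@@H]1O[C@H](CO)[C@@H](O)[C@H]1O`: 97 nM
Compound 2 `CNc1nc2c(SCc3ccccc3)ncnc2n1C1O[C@H](CO)[C@@H](O)[C@H]1O`: 28 nM
Compound 3 `CCCCNc1nc2c(SCc3ccccc3)ncnc2n1C1O[C@H](CO)[C@@H](O)[C@H]1O`: 5.4 nM

In an assay on cell membranes for binding affinity to Equilibrative nucleoside transporter 1 (Homo sapiens) (on this read-out lower numbers stand for stronger inhibition and higher numbers for weaker inhibition), compound 3 gives the lowest number of the three, with compound 2 the nearest and compound 1 the furthest. The unmeasured compound 4 `OC[C@H]1OC(n2c(NC3CCCCC3)nc3c(SCc4ccccc4)ncnc32)[C@H](O)[C@@H]1O` differs from compound 3 by cyclohexyl in place of butyl on a nitrogen on an aromatic ring. Within the data shown here, the only measured step at that nitrogen is a 5.2-fold lower number from compound 2 to compound 3 (0.71 log units; beyond the scatter), where lengthening the chain brought a modest gain. Compound 1 also carries a ring on an amino group, but at another place and with a different partner group, so its value is noted only for what it shows. Enlarging butyl to cyclohexyl at the same nitrogen is expected to hold the number near compound 3, with a 1.4-fold lower number from compound 3 to compound 4 (0.13 log units; within the scatter). Compound 4 is thus estimated at 4 nM, within 1.5 nM to 12 nM.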

Compound 4, inhibition constant: 0.94 nM
Compound 4: the middle estimate sits 4.3-fold (0.63 log units) above what was measured, outside the stated range (below it).
By their numbers in this assay, from the lowest: compound 4; then compound 3; then compound 2; then compound 1.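

In this assay, the gain at this nitrogen does not end with the butyl chain: cyclohexyl gives a 5.7-fold lower number from compound 3 to compound 4 (0.76 log units; beyond the scatter) and, measured against the methyl group, a 30-fold lower number from compound 2 to compound 4 (1.47 log units; beyond the scatter) on the same core. A six-membered carbon ring is therefore accepted here, and the lowest number of the series comes with it. Nothing measured here accounts for this gain. On these data alone, whether cycloheptyl, phenyl or a branched isopropyl group on the same nitrogen would go lower still remains open, as does the effect of a hydroxyl group on the cyclohexyl ring.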